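Acyl chain shortening in a glutamate receptor modulator series

The source may hold more compounds than are shown below. What is called first, only, known or untested is meant among the compounds shown, and "the series" means these compounds.

Compound 1 `CCCC(=O)c1ccc(OCCCCOc2ccc(F)c(C(=O)O)c2)c(C)c1O` stands highest of the two maximal responses measured so far: in an assay on HEK293 cells for positive allosteric modulation of metabotropic glutamate receptor 3 (Rattus norvegicus), read by thallium flux, with a stated time of 2.5 min (a higher number here means a larger maximal response, a lower number a smaller maximal response), compound 1 gives 56.9%. Going by the values given here, compound 2 `Cc1c(OCCCCOc2ccc(C(=O)O)cc2Cl)ccc(C(=O)CC2CCCC2)c1O` gives 27.4% in this assay, a gap beyond the scatter; the two structures differ in several places and no step between them is available. Compound 3 `CC(=O)c1ccc(OCCCCOc2ccc(F)c(C(=O)O)c2)c(C)c1O` differs from compound 1 by hydrogen in place of ethyl on a saturated chain carbon bound to a carbonyl carbon. Among the compounds with values here, no measured step covers such a change, so the expectation for compound 3 is a modest drop beyond the scatter, a number 12.9 percentage points lower from compound 1 to compound 3 (beyond the scatter), with wide uncertainty. Compound 3 is estimated at 44%, range 25% to 63%.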

Compound 3, largest response reached (reported as percent of maximum), in percent of the reference or control that the assay uses: 16.8%
Beside the measured number, compound 3's estimate is 27.2 percentage points above it, and the stated range ends above it.
By their numbers in this assay, from the lowest: compound 3; then compound 2; then compound 1.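

Working from the single-place step in this assay, hydrogen in place of ethyl on a saturated chain carbon bound to a carbonyl carbon gives a number 40.1 percentage points lower from compound 1 to compound 3 (beyond the scatter) with the rest of the structure unchanged. The maximal response therefore depends strongly on this position, and acetyl does not retain the level seen with propylcarbonyl. No measurement at hand explains the step.

Still open, as far as these compounds go, is how the response changes between methyl and propyl on the carbonyl carbon, as with an ethyl chain. Also open, from the compounds shown here alone, is whether a butyl or pentyl chain would raise or lower the response of compound 1.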